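Aromatic hydroxy placement on the shared core

The source may report more compounds than this note shows. Statements on the series, on what has been measured and on what is new or still open speak of the compounds shown alone.

Compound 1 `C=C1[C@](C)(O)CC[C@@]1(C)c1ccc(C)c(O)c1` carries a hydroxy group on the aromatic ring of the shared core. In a functional assay on BGC-823 cells (Homo sapiens) for cytotoxicity, read by MTT assay (a higher number here means a weaker inhibitor, a lower number a stronger inhibitor), compound 1 gives > 10 ug/mL, a limit of the assay rather than a number. Compound 2 `C=C1[C@](C)(O)CC[C@@]1(C)c1ccc(C)cc1` lacks that hydroxy. In this assay compound 2 gives > 10 ug/mL, again a limit and not a number. The step that the two limits leave unreadable from compound 1 to compound 2 has no readable size because of the limit of > 10 ug/mL in this assay, at which 2 of the 2 values shown sit. Compound 3 `C=C1[C@](C)(O)CC[C@@]1(C)c1ccc(C)cc1O` differs from compound 2 by hydroxy in place of hydrogen on an aromatic carbon. Going by the values given here, the only measured step touching an aromatic hydroxy is unreadable, so no step beyond the scatter is expected in this assay. The estimated change is a step that the limit leaves unreadable from compound 2 to compound 3. Compound 3 is expected at 20 ug/mL, range 8 ug/mL to 60 ug/mL, most likely reported as a limit once more.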

Compound 3, half-maximal inhibitory concentration: > 10 ug/mL
Compound 3: only a limit was reported; the forecaster's own chance of this, stated with the estimate: 85%; the middle value lies beyond the limit too.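

In this assay compound 3 gives > 10 ug/mL, a limit and not a number. No new step can be read between compound 2 and compound 3: the limit of > 10 ug/mL in this assay, at which 3 of the 3 values shown sit. The compounds shown leave open whether an aromatic hydroxy on the shared core changes the true potency in this assay.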